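A Phenylsulfanyl Group Gives Way to Hydroxy

The compounds below may be only part of what the source reports. "The series", "measured", "known", "first", "only" and "open" are said of these compounds alone.

Compound 1, drawn as `Nc1nc(O)c2c(n1)n(C1OC(CO)[C@@H](O)[C@H]1O)c(=O)n2CC(O)CSc1ccccc1`, is the weakest of three compounds tested in a functional assay (B cells) with Mus musculus as the target; a higher number here means that more compound is needed for the effect, a lower number that less compound is needed. In this assay compound 1 gives 142 uM, the highest number of the set. Compound 3, `C=CCn1c(=S)n(C2OC(COC(C)=O)[C@H]3OC(C)(C)O[C@@H]23)c2nc(N)nc(O)c21`, gives 50 uM, and compound 2, `C=CCn1c(=S)n(COCCO)c2nc(N)nc(O)c21`, gives 14 uM; both of these differ from compound 1 in several places at once, so their lower numbers cannot be tied to any single change.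

Compound 4, `Nc1nc(O)c2c(n1)n(C1OC(CO)[C@@H](O)[C@H]1O)c(=O)n2CC(O)CO`, has not yet been measured. It differs from compound 1 in one place: hydroxy in place of phenylsulfanyl on a saturated chain carbon, two bonds along the chain from an oxygen on a saturated carbon. A six-membered aromatic ring of carbon only leaves and a single oxygen bearing a hydrogen-bond donor enters, while the rest of the shared core and the sugar stay untouched.

Among the measured compounds shown here, no measured pair shows this exact change, so the step is uncertain. The step expected here is a 1.4-fold higher number from compound 1 to compound 4 (0.15 log units; within the scatter), a modest drift upward that may well sit inside the scatter. Compound 4 is therefore estimated at 200 uM, with a likely range from 60 uM to 650 uM.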

Compound 4, concentration for half-maximal effect: 45 uM
Estimate against measurement, compound 4: 4.4-fold (0.65 log units) above, and the stated range ends above it.
By their numbers in this assay, from the lowest: compound 2; then compounds 4 and 3 (each within the scatter of the next); then compound 1.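

Among the compounds shown here, this is the first change in the set that sits in one place only, so a shift in this assay can now be tied to this saturated chain carbon. The step is a 3.2-fold lower number from compound 1 to compound 4 (0.50 log units; beyond the scatter), which lies beyond the scatter. In this pair, the phenylsulfanyl group, with its aromatic ring and sulfur, is not required for the effect, and less compound is needed with hydroxy in its place. Nothing available here explains why the number falls with this change.

A single pair cannot show whether the loss of the ring, the loss of the sulfur or the arrival of hydroxy matters most. As far as these compounds go, an amine, a methoxy group or a longer chain ending in hydroxy on this carbon would help separate these possibilities, and whether the step holds on other parts of the molecule remains open.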